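This account rests on a few compounds, and the source may have more. Where it says the series, first, only, none or still open, it means among the compounds named here.

Values in an ADME assay on Huh-7 cells (Homo sapiens) for cytotoxicity, with a stated time of 72 h; a higher number here means that more compound is tolerated, a lower number that less compound is tolerated:
- Compound 1 `CS(=O)(=O)Nc1ccc2c(c1)S(=O)(=O)N=C(c1c(O)c(-c3cccs3)nn(CC3CCC3)c1=O)N2`: > 1000 nM
- Compound 2 `CC(C)CC(C)n1nc(-c2cccs2)c(O)c(C2=NS(=O)(=O)c3cc(NS(C)(=O)=O)ccc3N2)c1=O`: > 33000 nM

Compound 3 `CC(C)(C)Cn1nc(-c2cccs2)c(O)c(C2=NS(=O)(=O)c3cc(NS(C)(=O)=O)ccc3N2)c1=O` has not yet been measured.

Both entries are limits rather than numbers. Going by the values given here, compound 2 stands at > 33000 nM, which is a limit and says only that the true value was not reached. Compound 1 reads > 1000 nM, which is also a limit.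

Compound 3 carries neopentyl in place of 1,3-dimethylbutyl on an aromatic nitrogen, and the counted difference is neopentyl in place of 1,3-dimethylbutyl on an aromatic nitrogen. Among the compounds with values here, the group on this same kind of nitrogen also changes in the one measured step that bears on this: a step that the two limits leave unreadable from compound 1 to compound 2. That step has no readable size, so it offers no direct guide to how much such a change can matter.

With no measured size to build on, the best guide is compound 2 at > 33000 nM, a limit that suggests good tolerance in this assay. The expected result is no change beyond the usual scatter, with an estimated a number no higher from compound 2 to compound 3 (the limit leaves the size open). For compound 3 the estimated value is 33000 nM, expected to fall between 12000 nM and 90000 nM, and it may well be reported only as a limit.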

Compound 3, half-maximal cytotoxic concentration: > 1000 nM
Compound 3: no number, only a limit (the forecaster's own chance of this, stated with the estimate: 75%); the middle value lies beyond the limit too.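

In this assay compound 3 gives > 1000 nM, which is a limit and not a number. Compound 1 and compound 2 are also reported only as limits, so no step among these three compounds can be read. The compounds shown leave open how much of each is actually tolerated, and whether swapping the group on the aromatic nitrogen changes that at all.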